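Notes on the series: the step from compound 2 to compound 4

The source may hold more compounds than are shown below. What is called first, only, known or untested is meant among the compounds shown, and "the series" means these compounds.

Compound 1 `[O-][S+](CCNC1CCN(Cc2ccc(F)cc2)CC1)C(c1ccc(F)cc1)c1ccc(F)cc1`, compound 2 `OC(Cc1ccccc1)CN1CCC(NCCSC(c2ccc(F)cc2)c2ccc(F)cc2)CC1` and compound 3 `O=C(c1ccc(F)cc1)N1CCC(NCC[S+]([O-])C(c2ccc(F)cc2)c2ccc(F)cc2)CC1` share a core and differ in the group on the amine nitrogen in the ring and at the sulfur. In an ADME assay on microsomes from liver (Rattus norvegicus) for metabolic stability, read by LC-MS, using NADPH, with a stated time of 60 min, tested at 10 uM (on this read-out lower numbers stand for a less stable compound and higher numbers for a more stable compound), compound 1 gives 95%, compound 3 gives 79% and compound 2 gives 74%. Compound 2 holds the lowest of the three numbers; its value lies within the scatter of compound 3 and beyond the scatter below compound 1. The single-point step measured so far, a number 16 percentage points lower from compound 1 to compound 3 (beyond the scatter), concerns the exchange of a benzyl-type group for a carbonyl-bearing group on that nitrogen. Compound 4 `O=C(c1ccc(F)cc1F)N1CCC(NCCSC(c2ccc(F)cc2)c2ccc(F)cc2)CC1` has not yet been measured; it differs from compound 2 by (2,4-difluorophenyl)carbonyl in place of 2-hydroxy-3-phenylpropyl on an amine nitrogen in a ring. Going by the values given here, no measured step covers this exact exchange, and compound 4 keeps the sulfur of compound 2 rather than that of compound 3, so any comparison to compound 3 is indirect. Compound 3, which also carries a carbonyl on the same nitrogen, gives 79%, close to the value of compound 2. The expected step from compound 2 to compound 4 is therefore a number 1 percentage points higher from compound 2 to compound 4 (within the scatter), within the scatter. Compound 4 is estimated at 75%, with a range from 60% to 88%.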

Compound 4, percent of the compound remaining: 85%
For compound 4 the middle estimate is 10 percentage points below the measured one; the measured number falls inside the stated range.
By their numbers in this assay, from the lowest: compounds 2, 3, 4 and 1 (each within the scatter of the next, the first and the last beyond it).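

In this assay the amine nitrogen in the ring now shows an upward step with the sulfur left unchanged, a number 11 percentage points higher from compound 2 to compound 4 (beyond the scatter), for (2,4-difluorophenyl)carbonyl in place of 2-hydroxy-3-phenylpropyl. Going by these compounds alone, the only earlier step at this nitrogen ran the other way, a number 16 percentage points lower from compound 1 to compound 3 (beyond the scatter), so a carbonyl-bearing group here is no longer tied to a lower number, although the two steps start from different groups and differ at the sulfur. Neither the heavy-atom count nor the aromatic ring count changes in the new exchange, so the step arises with both held level.

No measurement shown bears on what lies behind the step. As far as these compounds go, the exchange alters the hydroxyl, the carbonyl and the fluorines together, so it remains open how much of the step would survive with a plain 3-phenylpropyl chain or an unsubstituted phenylcarbonyl on this nitrogen, and whether the same exchange would hold with an oxygen on the sulfur.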